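Replacing a thiocarbonyl group on the ring nitrogen

The source may hold more compounds than are shown below. What is called first, only, known or untested is meant among the compounds shown, and "the series" means these compounds.

Measured compounds:
compound 1, `Cc1nc(S(C)(=O)=O)ccc1Oc1ncnc(OC2CCN(C(=O)O[C@@H](C)C(F)(F)F)CC2)c1F`, 9.86 nM
compound 2, `Cc1nc(S(C)(=O)=O)ccc1Oc1ncnc(OC2CCN(C(=O)SC3CCC3)CC2)c1F`, 8.51 nM
compound 3, `Cc1nc(S(C)(=O)=O)ccc1Oc1ncnc(OC2CCN(C(=S)OC(C)C)CC2)c1F`, 69.9 nM

In a functional assay on isolated protein for inhibition of Glucose-dependent insulinotropic receptor (Homo sapiens), read by HTRF and cAMP accumulation (on this read-out lower numbers stand for an effect already at smaller amounts and higher numbers for an effect only at larger amounts of compound), compound 3 stands highest of the three numbers, with a 7.1-fold higher number from compound 1 to compound 3 (0.85 log units; beyond the scatter) and an 8.2-fold higher number from compound 2 to compound 3 (0.91 log units; beyond the scatter) both beyond the scatter, while a 1.2-fold lower number from compound 1 to compound 2 (0.06 log units; within the scatter) lies within it. Compound 4, `CCc1cnc(C(=O)N2CCC(Oc3ncnc(Oc4ccc(S(C)(=O)=O)nc4C)c3F)CC2)nc1`, differs from compound 3 in this way: a group of 10 heavy atoms (7 carbon, 2 nitrogen, 1 oxygen; one six-membered aromatic ring with 2 hetero atoms) in place of a group of 6 heavy atoms (4 carbon, 1 oxygen, 1 sulfur; no ring), on an amine nitrogen in a ring. The relevant comparisons are those of compound 1 and compound 2 against compound 3: both compounds without the thiocarbonyl gave lower numbers, beyond the scatter. Compound 4 likewise has a carbonyl rather than a thiocarbonyl on that nitrogen, so a step back down toward the range of compound 1 and compound 2 is expected, namely a 5.8-fold lower number from compound 3 to compound 4 (0.77 log units; beyond the scatter). The estimated value for compound 4 is 12 nM, with a range from 4 nM to 40 nM.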

Compound 4, half-maximal effective concentration: 4.7 nM
Beside the measured number, compound 4's estimate is 2.6-fold (0.41 log units) above it; the measured number falls inside the stated range.
By their numbers in this assay, from the lowest: compounds 4, 2 and 1 (each within the scatter of the next, the first and the last beyond it); then compound 3.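

Compound 4 shows that this carbonyl can carry 5-ethylpyrimidin-2-yl, an aromatic ring, in place of the open or sulfur-linked groups, and the number stays low: a 1.8-fold lower number from compound 2 to compound 4 (0.26 log units; within the scatter) is within the scatter, while a 2.1-fold lower number from compound 1 to compound 4 (0.32 log units; beyond the scatter) is a modest step beyond it. The large 15-fold lower number from compound 3 to compound 4 (1.17 log units; beyond the scatter) combines the loss of the thiocarbonyl with the arrival of the ring, and the two changes cannot be separated here. No measurement offered here explains these steps.

Open, as far as these compounds go, is whether the ethyl matters: a methyl or a longer chain on the pyrimidine could answer that. Also open, from the compounds shown here alone, is whether a phenyl ring would serve as well as the pyrimidine.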